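Solubility notes: a furan-2-yl variant of compound 3

A few compounds are considered here, and "the series" means these few. Any claim that something is new, unique, unknown or untested is made for them only; others in the source may bear on it.

Among the measured compounds shown here, compound 3 `COc1cccc(CNCCCNc2ccnc3cc(-c4cc(C(F)(F)F)cc(C(F)(F)F)c4)ccc23)c1O` gives the highest solubility of the three compounds measured so far. In a physicochemical assay for solubility, with a stated time of 18 h, at pH 7.4 (on this read-out lower numbers stand for lower solubility and higher numbers for higher solubility), compound 3 gives 32000 nM. The nearest number belongs to compound 1 `COc1ccc(Oc2ccc3c(NCCCNCc4cc(F)ccc4OC)ccnc3c2)cc1`, which in this assay gives 14500 nM, a gap beyond the usual scatter. Compound 2 `COc1cccc(CNCCCNc2ccnc3cc(CCC(C)C)ccc23)c1O` lies furthest away and in this assay gives 4200 nM, again beyond the scatter. For the measured compounds named here, no two of these three compounds differ in only one place, so no single step between measured compounds is available for comparison.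

Compound 4 `FC(F)(F)c1cc(-c2ccc3c(NCCCNCc4ccco4)ccnc3c2)cc(C(F)(F)F)c1` is not yet measured. It differs from compound 3 in one place: furan-2-yl in place of 2-hydroxy-3-methoxyphenyl on a saturated chain carbon bound to an amine nitrogen. The group that leaves carries 1 hydrogen-bond donor and 2 hydrogen-bond acceptors; the group that enters carries 0 hydrogen-bond donors and 1 hydrogen-bond acceptor.

Going by the values given here, with no comparable step among the measured compounds, the size of the step can only be estimated. A downward step in this assay is expected, estimated at a 2.1-fold lower number from compound 3 to compound 4 (0.33 log units; beyond the scatter), and it may reach beyond the scatter. Compound 4 is therefore estimated at 15000 nM, with a range from 5000 nM to 40000 nM.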

Compound 4, solubility: 32000 nM
Estimate against measurement, compound 4: 2.1-fold (0.33 log units) below, and the stated range covers the measured number.
By their numbers in this assay, from the lowest: compound 2; then compound 1; then compounds 3 and 4 (each within the scatter of the next).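

In this assay, among the compounds shown here, furan-2-yl in place of 2-hydroxy-3-methoxyphenyl on a saturated chain carbon bound to an amine nitrogen gives no change at the digits printed from compound 3 to compound 4 (within the scatter), the first single-place comparison. At this position, then, the read-out holds although the entering group has fewer heavy atoms, a five-membered aromatic ring with 1 hetero atom in place of a six-membered ring of carbon only, fewer hydrogen-bond acceptors and no hydrogen-bond donor. No evidence at hand accounts for this result.

On these data alone, it remains open whether a carboxylic acid or a morpholine at this place would shift the number in this assay beyond the scatter. Also open, as far as these compounds go, is whether the same exchange would give a similar step on compound 2, which carries the same 2-hydroxy-3-methoxyphenyl group but a different substituent on the shared core.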